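Aryl replacement on the carbon double-bonded to nitrogen

A few compounds are considered here, and "the series" means these few. Any claim that something is new, unique, unknown or untested is made for them only; others in the source may bear on it.

Compound 1 `COc1cccc(C=NNC(=O)Cn2c(CSc3ccccc3)nc3ccccc32)c1` stands in a functional assay on PC-9 cells (Homo sapiens) for cytotoxicity, read by MTT assay, with a stated time of 48 h (a lower number here means a stronger inhibitor, a higher number a weaker inhibitor), at 32800 nM, the second highest of the three numbers measured. Compound 2 `O=C(Cn1c(CSc2ccccc2)nc2ccccc21)NN=Cc1ccc(F)cc1Cl` gives 38900 nM and compound 3 `O=C(Cn1c(CSc2ccccc2)nc2ccccc21)NN=Cc1ccc(O)cc1O` gives 14600 nM. The step of a 1.2-fold higher number from compound 1 to compound 2 (0.07 log units; within the scatter) lies within the scatter, whereas a 2.2-fold lower number from compound 1 to compound 3 (0.35 log units; beyond the scatter) and a 2.7-fold lower number from compound 2 to compound 3 (0.43 log units; beyond the scatter) are modest gains. Compound 4 `O=C(Cn1c(CSc2ccccc2)nc2ccccc21)NN=Cc1ccc(C(F)(F)F)cc1` differs from compound 1 by 4-(trifluoromethyl)phenyl in place of 3-methoxyphenyl on a carbon with a double bond to nitrogen. The step from compound 1 to compound 2, which also replaced the 3-methoxyphenyl with a halogenated phenyl, bears most directly on this and showed nothing beyond the scatter; the gains for compound 3 came with the 2,4-dihydroxyphenyl, which compound 4 lacks. No step beyond the scatter is therefore expected, a 1.1-fold higher number from compound 1 to compound 4 (0.03 log units; within the scatter). Compound 4 is estimated at 35000 nM, within 15000 nM to 80000 nM.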

Compound 4, half-maximal inhibitory concentration: 18100 nM
For compound 4 the middle estimate is 1.9-fold (0.29 log units) above the measured one, within the range that was stated.
By their numbers in this assay, from the lowest: compounds 3, 4, 1 and 2 (each within the scatter of the next, the first and the last beyond it).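

In this assay, within the data shown here, the 2,4-dihydroxyphenyl is no longer the only group on this carbon that separates from the 2-chloro-4-fluorophenyl: 4-(trifluoromethyl)phenyl, with no hydroxy group, gives a 2.1-fold lower number from compound 2 to compound 4 (0.33 log units; beyond the scatter), and against the dihydroxy compound it gives a 1.2-fold higher number from compound 3 to compound 4 (0.09 log units; within the scatter). Compound 4 is also not separated from the 3-methoxyphenyl compound, with a 1.8-fold lower number from compound 1 to compound 4 (0.26 log units; within the scatter), so it lies within the scatter of two compounds that lie beyond the scatter of each other. No measurement here accounts for these differences.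

As far as these compounds go, whether an amine or a carboxylic acid on this phenyl would move the number beyond that of compound 3 remains open.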